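Trifluoromethyl in place of fluoro at the anilide ring

A few compounds are considered here, and "the series" means these few. Any claim that something is new, unique, unknown or untested is made for them only; others in the source may bear on it.

Of the compounds shown here, three sharing one core have been measured in a functional assay on the whole organism (strain Swiss) with Mus musculus as the target, in the maximal electroshock model, with a stated time of 0.5 h, at a dose of 300 mg/kg by the intraperitoneal route; on this read-out lower numbers stand for a weaker effect and higher numbers for a stronger effect at the one dose given. Compound 3 `CCC(C(=O)N1CCN(c2ccccc2F)CC1)N1C(=O)CCC1=O` gives 100%, the highest of the three numbers. Its nearest neighbour is compound 1 `CCC(C(=O)N1CCN(c2ccccc2Cl)CC1)N1C(=O)CCC1=O`, which gives 25%, and the furthest is compound 2 `CCC(C(=O)N1CCN(c2cccc(OC)c2)CC1)N1C(=O)CCC1=O`, which gives 0%. Both of those gaps lie beyond the scatter: a number 75 percentage points higher from compound 1 to compound 3 (beyond the scatter) and a number 100 percentage points higher from compound 2 to compound 3 (beyond the scatter).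

Compound 4 `CCC(C(=O)N1CCN(c2ccccc2C(F)(F)F)CC1)N1C(=O)CCC1=O` differs from compound 3 in one place: trifluoromethyl in place of fluoro on an aromatic carbon. The step that bears most directly on this change is the one at the same aromatic carbon, a number 75 percentage points higher from compound 1 to compound 3 (beyond the scatter), which shows that exchanging one halogen for another at this position moved the read-out by a large amount. For the measured compounds named here, a further change at the same spot is therefore expected to shift the read-out in this assay again, and the one measured exchange points downward from the fluoro compound.

On that basis compound 4 is estimated to give 25%, within a range of 0% to 75%. The step this estimate implies is a number 75 percentage points lower from compound 3 to compound 4 (beyond the scatter), expected to fall beyond the scatter.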

Compound 4, a percentage reported as activity, at one dose (the size of the read-out at that dose, not a potency): 25%
The estimate for compound 4 equals the measured number at the digits printed, and the stated range covers the measured number.
By their numbers in this assay, from the lowest: compound 2; then compounds 1 and 4 (each within the scatter of the next); then compound 3.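

In this assay, the new result shows that fluoro is not simply one of several interchangeable groups on this aromatic carbon, ortho to a large group: the exchange for trifluoromethyl gives a number 75 percentage points lower from compound 3 to compound 4 (beyond the scatter). The second replacement of fluoro now lands with the first, since the exchange of chloro for trifluoromethyl gives no change at the digits printed from compound 1 to compound 4 (within the scatter), so the drop seen earlier with chloro is no longer a single case. Nothing available here explains why fluoro stands apart from these two groups.

On these data alone, whether any group other than fluoro can match compound 3 on this carbon remains open, and a methyl group or a nitrile would be among the untested possibilities here. The compounds shown also leave open whether this ordering would hold at other doses or times.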